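The compounds below may be only part of what the source reports. "The series", "measured", "known", "first", "only" and "open" are said of these compounds alone.

Compound 1 `Fc1ccc(C2CC(c3ccc(Cl)s3)=NN2c2nc(-c3ccc(Cl)cc3)cs2)cc1`: > 500 ug/mL. Compound 2 `COc1ccc(-c2csc(N3N=C(c4ccc(Cl)s4)CC3c3ccc(F)cc3)n2)cc1`: 103 ug/mL.

In an ADME assay on NIH3T3 cells (Mus musculus) for cytotoxicity, read by XTT assay, with a stated time of 24 h (a lower number here means a stronger inhibitor, a higher number a weaker inhibitor), compound 1 gives > 500 ug/mL, which is a limit of the assay rather than a number. Compound 1 thus stands at the limit of > 500 ug/mL in this assay, at which 1 of the 2 values shown sits, so only a range is known for it. Compound 2 gives 103 ug/mL in this assay, and the step of an at least 4.8-fold lower number from compound 1 to compound 2 (0.68 log units; beyond the scatter) came with methoxy in place of chloro on an aromatic carbon. Compound 3 `Cc1ccc(C2=NN(c3nc(-c4ccc(Cl)cc4)cs3)C(c3ccc(F)cc3)C2)s1` differs from compound 1 by methyl in place of chloro on an aromatic carbon. Going by the values given here, the single measured step concerns another group at another place, so it bears only loosely on this change. No step beyond the scatter is expected, the estimate being an at least 1.2-fold lower number from compound 1 to compound 3 (0.09 log units; that floor lies within the scatter). Compound 3 is therefore expected at 400 ug/mL, with a range from 100 ug/mL to 1000 ug/mL.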

Compound 3, half-maximal inhibitory concentration: > 500 ug/mL
Compound 3: a limit, no number (the forecaster's own chance of this, stated with the estimate: 60%); at least 1.2-fold (0.09 log units) between middle value and limit.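

Compound 1 and compound 3 both sit at a limit of the assay rather than at a number, so no step can be read between them: the limit of > 500 ug/mL in this assay, at which 2 of the 3 values shown sit. Going by these compounds, whether 5-chlorothiophen-2-yl and 5-methylthiophen-2-yl differ at all in this assay stays open.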